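The source may hold more compounds than are shown below. What is called first, only, known or untested is meant among the compounds shown, and "the series" means these compounds.

Measured in an ADME assay on L6 cells (Rattus norvegicus) for cytotoxicity; a lower number here means a stronger inhibitor, a higher number a weaker inhibitor:
compound 1, `O=C1CC2(N3CCCC3)CC(c3ccccc3)C1C(c1ccccc1)C2`, gives 26500 nM
compound 2, `O=C1CC2(N3CCCCC3)CC(c3ccccc3)C1C(c1ccccc1)C2`, gives 46900 nM
compound 3, `OC1CC2(N3CCCC3)CC(c3ccc(Cl)cc3)C1C(c1ccc(Cl)cc1)C2`, gives 3590 nM

Compound 4, `OC1CC2(N3CCCCC3)CC(c3ccc(Cl)cc3)C1C(c1ccc(Cl)cc1)C2`, has no number yet in this assay. It differs from compound 3 by piperidin-1-yl in place of pyrrolidin-1-yl on a saturated ring carbon. The same kind of change has been measured once, between compound 1 and compound 2: piperidin-1-yl in place of pyrrolidin-1-yl on a saturated ring carbon, which gave a 1.8-fold higher number from compound 1 to compound 2 (0.25 log units; within the scatter). Around the place the two pairs are not identical: in the pair from compound 1 the ring atom bears a phenyl group, while in the pair from compound 3 it bears a 4-chlorophenyl group and a further ring atom bears a hydroxy group. How the core of compound 3 differs from the core of compound 1 is not broken down here; the values show compound 3 set well apart from both compound 1 and compound 2 in this assay. Going by the values given here, for compound 4 a similarly small step is expected, a 1.8-fold higher number from compound 3 to compound 4 (0.26 log units; within the scatter), because the only measured example of this change is a 1.8-fold higher number from compound 1 to compound 2 (0.25 log units; within the scatter). Compound 4 is therefore estimated at 6500 nM, expected to fall between 3300 nM and 13000 nM.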

Compound 4, half-maximal inhibitory concentration: 11600 nM
The estimate for compound 4 lay 1.8-fold (0.25 log units) below the measured number; the measured number falls inside the stated range.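

In this assay, piperidin-1-yl in place of pyrrolidin-1-yl gives a 3.2-fold higher number from compound 3 to compound 4 (0.51 log units; beyond the scatter). Set beside the earlier pair, this step cannot be told apart from the first, so the change carries across these two cores without a measurable difference in step size: the same change on two cores in this assay, a 1.8-fold higher number (0.25 log units; within the scatter) from compound 1 to compound 2 and a 3.2-fold higher number (0.51 log units; beyond the scatter) from compound 3 to compound 4, 1.8-fold (0.26 log units) apart, within the scatter of two such steps. Two pairs do not establish a general rule, and the cores differ in more than one place, so they do not show whether any single core feature affects the step.

The separate contributions of the hydroxy group and the 4-chlorophenyl group remain open, as these two differences occur together in the compounds shown. Also open, as far as these compounds go, is how morpholin-4-yl or an open-chain dimethylamino group would compare on the same saturated ring carbon.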